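A few compounds are considered here, and "the series" means these few. Any claim that something is new, unique, unknown or untested is made for them only; others in the source may bear on it.

Compound 1 `CCc1nc(N)c2nc(O)n(Cc3ccccc3)c2n1`: 3 mg/kg
Compound 2 `CCCNc1nc(N)c2nc(O)n(Cc3ccccc3)c2n1`: 1 mg/kg
Compound 3 `Nc1ncnc2c1nc(S)n2Cc1ccccc1`: > 30 mg/kg, a limit

All three were tested in a functional assay on the whole organism for activation, with Mus musculus as the target; on this read-out higher numbers stand for an effect only at larger amounts of compound and lower numbers for an effect already at smaller amounts. Compound 1 gives 3 mg/kg. Compound 2 gives 1 mg/kg, the lowest of the two numbers shown. For compound 3 the assay reports only a limit, namely (the limit of > 30 mg/kg in this assay, at which 1 of the 3 values shown sits). For the measured compounds named here, the one step between measured compounds that differ in a single place is a 3.0-fold lower number from compound 1 to compound 2 (0.48 log units; beyond the scatter), a modest step that lies beyond the scatter.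

Compound 4 `CCCc1nc(N)c2nc(O)n(Cc3ccccc3)c2n1` is still to be measured. It differs from compound 2 in one place: propyl in place of propylamino on an aromatic carbon. Going by the values given here, no measured step swaps propylamino for propyl, so the only guide is the step from compound 1 to compound 2, which lengthened the chain and brought in the nitrogen together. Propyl keeps the carbon chain of propylamino and drops the nitrogen, so compound 4 is expected to sit close to compound 2 in this assay. The step of a 2.0-fold higher number from compound 2 to compound 4 (0.30 log units; within the scatter) is expected to stay small. For compound 4 the expected value is 2 mg/kg, within a range from 0.7 mg/kg to 6 mg/kg.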

Compound 4, minimum effective dose: 3 mg/kg
Compound 4: middle estimate off by 1.5-fold (0.18 log units), on the low side; low and high end bracket the measured number.
By their numbers in this assay, from the lowest: compound 2; then compounds 1 and 4 (each within the scatter of the next). At a limit, above all of these: compound 3.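

In this assay the swap of propylamino for propyl gives a 3.0-fold higher number from compound 2 to compound 4 (0.48 log units; beyond the scatter) while the carbon chain stays the same, so on this aromatic carbon only the nitrogen separates the two groups. Methyl in place of hydrogen on the ethyl chain gives no change at the digits printed from compound 1 to compound 4 (within the scatter) and so a longer carbon chain on its own does not move the number here. Taken together, the lower number of compound 2 goes with the nitrogen of propylamino rather than with the extra chain length, two changes that the earlier step could not pull apart.

Going by these compounds, it remains open whether a propoxy group would behave like propylamino or like propyl, and whether a shorter ethylamino or a longer butylamino group would shift the number. No measurement shown explains why the nitrogen makes this difference.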